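This account rests on a few compounds, and the source may have more. Where it says the series, first, only, none or still open, it means among the compounds named here.

Among the measured compounds shown here, in an ADME assay on HOS cells (Homo sapiens) for cytotoxicity (a lower number here means that less compound is tolerated, a higher number that more compound is tolerated), compound 3 `CN(Cc1nc2cccc(CCCN)c2[nH]1)C1CCCc2cccnc21` gives 10000 nM, the higher of the two exact numbers so far. Compound 1 `CN(Cc1nc2ccccc2n1CCCCCN)C1CCCc2cccnc21` gives 4500 nM, lower by a margin beyond the scatter. Compound 2 `CN(Cc1nc2cccc(CNCCN)c2[nH]1)C1CCCc2cccnc21` reads > 20000 nM, which is a limit of the assay and not a number.

Compound 4 `CN(Cc1nc2cccc(N3CCNCC3)c2[nH]1)C1CCCc2cccnc21` has piperazin-1-yl in place of 3-aminopropyl on an aromatic carbon. For the measured compounds named here, the one measured step that bears on this change is an at least 2.0-fold lower number from compound 2 to compound 3 (0.30 log units; that floor lies within the scatter), which also alters a side chain on the shared core, and its floor lies within the scatter. That step gives no firm direction, so in this assay the expected step is small, a 1.2-fold higher number from compound 3 to compound 4 (0.08 log units; within the scatter), within the scatter. Compound 4 is estimated at 12000 nM, with an expected range of 5000 nM to 20000 nM.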

Compound 4, half-maximal cytotoxic concentration: > 20000 nM
Compound 4: no number, only a limit (the forecaster's own chance of this, stated with the estimate: 25%); middle value at least 1.6-fold (0.22 log units) away from the limit.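

In this assay there is an at least 2.0-fold higher number from compound 3 to compound 4 (0.30 log units; that floor lies within the scatter) when the piperazin-1-yl ring replaces the open 3-aminopropyl chain on this aromatic carbon. This shows that a ring attached directly at this place is tolerated as well as the chains of compound 2 and compound 3, though the floor of this step alone gives no firm rise. The step between compound 2 and compound 4 cannot be read, because each stops at a limit and not a number: the limit of > 20000 nM in this assay, at which 2 of the 4 values shown sit.

Still open, going by these compounds, is how a morpholine ring or a plain primary amine on this same aromatic carbon would read in this assay and whether either would also stop at the limit.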